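Removing One Chloro from a Dichloropurine Cytotoxin

The source may hold more compounds than are shown below. What is called first, only, known or untested is meant among the compounds shown, and "the series" means these compounds.

Going by the values given here, compound 2 `ClCc1ccccc1Cn1cnc2c(Cl)nc(Cl)nc21` is one of two compounds so far tested in a functional assay on HCT-15 cells (Homo sapiens) for cytotoxicity, read by sulforhodamine B assay, with a stated time of 48 h; a higher number here means that more compound is tolerated, a lower number that less compound is tolerated. In this assay compound 2 gives 4780 nM, the lowest of the two numbers. The other compound, compound 1 `ClCc1ccc(Cn2cnc3c(Cl)ncnc32)cc1`, gives 63100 nM in this assay, a gap that lies well beyond the scatter. Among the compounds with values here, compound 1 and compound 2 differ in more than one place, so no single step joins them and the numbers can only be set side by side.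

Compound 3 `ClCc1ccccc1Cn1cnc2c(Cl)ncnc21` has not yet been measured in this assay. It differs from compound 2 in exactly one place: hydrogen in place of chloro on an aromatic carbon, the carbon between two ring nitrogen atoms, meta to the remaining chloro group. Within the data shown here, no measured pair shows what this change does on its own. The expectation is a moderate rise in the number, beyond the scatter but short of the gap separating compound 1 from compound 2. Compound 3 is estimated at 15000 nM in this assay, within a range from 4000 nM to 50000 nM. That estimate means an expected step of a 3.1-fold higher number from compound 2 to compound 3 (0.50 log units; beyond the scatter) in this assay.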

Compound 3, concentration lethal to 50% of the cells: 43700 nM
For compound 3 the middle estimate is 2.9-fold (0.46 log units) below the measured one; the range from low to high includes it.
By their numbers in this assay, from the lowest: compound 2; then compounds 3 and 1 (each within the scatter of the next).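

Going by these compounds alone, the step of a 9.1-fold higher number from compound 2 to compound 3 (0.96 log units; beyond the scatter) in this assay is the first reading of this change on its own, since compound 1 and compound 2 differ in more than one place and could only be set side by side. It shows that the chloro group on the aromatic carbon between two ring nitrogen atoms is not a silent substituent here: with hydrogen in its place and the remaining chloro group and the chloromethyl benzyl part unchanged, the number moves beyond the scatter, towards more compound being tolerated. Nothing shown accounts for the size of this step.

The compounds shown hold only chloro or hydrogen at this carbon, so what an amine or a methoxy group would do there remains open. Compound 1 also carries hydrogen at this carbon, but it has no chloro partner among the compounds shown, so it also remains open whether the step keeps its size when the chloromethyl group sits where it does in compound 1.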